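This account rests on a few compounds, and the source may have more. Where it says the series, first, only, none or still open, it means among the compounds named here.

Two compounds share one core and differ only in one group on the amine nitrogen. Compound 1 `Cc1ccc2[nH]c(=O)c(CN(Cc3ccccc3)Cc3ccc(C(C)(C)C)cc3)cc2c1` carries a benzyl group there. In a toxicity assay on MDCK cells (Canis lupus familiaris) for cytotoxicity, read by crystal violet staining, with a stated time of 48 h (on this read-out lower numbers stand for higher toxicity in this test and higher numbers for lower toxicity in this test), compound 1 gives > 5000 nM, which is a limit of the assay rather than a number. Compound 2 `Cc1ccc2[nH]c(=O)c(CN(Cc3ccc(C#N)cc3)Cc3ccc(C(C)(C)C)cc3)cc2c1` carries a 4-cyanobenzyl group instead. In this assay compound 2 gives > 5000 nM, again a limit and not a number. The step that the two limits leave unreadable from compound 1 to compound 2 is therefore not readable, since both values sit at the limit of > 5000 nM in this assay, at which 2 of the 2 values shown sit.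

Compound 3 `Cc1ccc2[nH]c(=O)c(CN(Cc3ccc(C(C)(C)C)cc3)C(C)c3ccc(F)cc3)cc2c1` is not yet measured. Its change from compound 2 is 1-(4-fluorophenyl)ethyl in place of 4-cyanobenzyl on an amine nitrogen. Going by the values given here, no measured step bears on this change, and the one step available is itself unreadable, so the only expectation is that compound 3 stays where both neighbours sit. The step that the limit leaves unreadable from compound 2 to compound 3 is accordingly expected to be small. Compound 3 is expected to give 8000 nM, with a range from 3000 nM to 30000 nM.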

Compound 3, half-maximal cytotoxic concentration: > 33000 nM
Compound 3 ended at the assay's limit (the forecaster's own chance of this, stated with the estimate: 75%); middle value at least 4.1-fold (0.61 log units) from the limit.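

Going by these compounds alone, compound 3 gives > 33000 nM, again a limit of the assay and not a number, so no step from compound 1 or compound 2 to compound 3 can be read. The compounds shown leave open whether changing the group on the amine nitrogen alters toxicity at all.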